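Swapping Acetoxy for Anilino: What to Expect

The source may hold more compounds than are shown below. What is called first, only, known or untested is meant among the compounds shown, and "the series" means these compounds.

Compound 1 `COCC1=CS(=O)(=O)c2ccccc2C1=O` and compound 2 `CC(=O)OCC1=CS(=O)(=O)c2ccccc2C1=O` share one core and differ only in the group carried by an oxygen on a saturated carbon. In a functional assay on the whole organism for inhibition, with Mus musculus as the target, at a dose of 10 mg/kg (on this read-out lower numbers stand for less inhibition and higher numbers for more inhibition at the one dose given (going by the name of the read-out)), compound 1 gives 99.9%, and compound 2 gives 99.5%. Compound 2 stands right alongside compound 1: the step of a number 0.4 percentage points lower from compound 1 to compound 2 (within the scatter) lies inside the usual scatter, so the two are not told apart. Compound 3 `O=C1C(CNc2ccccc2)=CS(=O)(=O)c2ccccc21` has not yet been measured. It differs from compound 2 in one place: anilino in place of acetoxy on a saturated chain carbon bound to a double-bonded ring carbon. Going by the values given here, the single measured step bears only loosely on this change, since it swapped one group on the oxygen for another, whereas here acetoxy leaves entirely and anilino enters. Among the compounds with values here, with the numbers measured so far both high, a step of a number 4.5 percentage points lower from compound 2 to compound 3 (within the scatter) is expected, probably small. Compound 3 is therefore estimated at 95%, within a range from 70% to 100%.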

Compound 3, a percentage reported as inhibition, in the whole organism at one dose (the size of the read-out at that dose, not a potency): 0%
The estimate for compound 3 lay 95 percentage points above the measured number; measured number outside the range, below it.
By their numbers in this assay, from the lowest: compound 3; then compounds 2 and 1 (each within the scatter of the next).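

Replacing acetoxy with anilino on a saturated chain carbon bound to a double-bonded ring carbon gives a number 99.5 percentage points lower from compound 2 to compound 3 (beyond the scatter) in this assay, and replacing methoxy there gives a number 99.9 percentage points lower from compound 1 to compound 3 (beyond the scatter) in the same assay. Going by these compounds alone, the earlier pair showed only that two groups attached through oxygen could not be told apart, whereas these steps show that this position is far from indifferent to what it carries. No measurement available here accounts for the size of these steps.

Anilino brings a nitrogen and an aromatic ring together, so the compounds shown cannot say which of the two goes with the lost inhibition. Phenoxy, which keeps the ring on an oxygen, and dimethylamino, which keeps a nitrogen without the ring, would help separate the two.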